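Swapping a methylphenyl for a pyridinyl on a shared core

This account rests on a few compounds, and the source may have more. Where it says the series, first, only, none or still open, it means among the compounds named here.

Three close relatives share one core. In a functional assay on HCT-116 cells (Homo sapiens) for inhibition, read by MTT assay, with a stated time of 24 h, tested at 2.5 uM (a lower number here means less inhibition of growth, a higher number more inhibition of growth at the concentration tested), compound 1 `N#Cc1ccc(-c2cnc3[nH]cc(-c4nnc(-c5ccc(Cl)cc5)o4)c(=O)c3c2)cc1` gives 13.7%. Among the measured compounds shown here, compound 2 `N#Cc1ccc(-c2cnc3[nH]cc(-c4nnc(-c5ccc(F)cc5)o4)c(=O)c3c2)cc1` gives 10.2% in this assay, and its single change, fluoro in place of chloro on an aromatic carbon, moves the number by a number 3.5 percentage points lower from compound 1 to compound 2 (within the scatter). Compound 3 `Cc1ccc(-c2nnc(-c3c[nH]c4ncc(-c5ccc(S(C)(=O)=O)cc5)cc4c3=O)o2)cc1` gives 7.47% in this assay; its gaps to compound 2 and to compound 1 both fall within the scatter, so the three numbers sit together and none of them can be called more or less active than another. Compound 4 `CS(=O)(=O)c1ccc(-c2cnc3[nH]cc(-c4nnc(-c5ccccn5)o4)c(=O)c3c2)cc1` has not yet been measured. It differs from compound 3 in one place: pyridin-2-yl in place of 4-methylphenyl on an aromatic carbon. For the measured compounds named here, no measured step trades one aromatic ring for another on the five-membered aromatic ring with 2 nitrogen and 1 oxygen; the only measured step, the halogen change from compound 1 to compound 2, stayed within the scatter. With nothing pointing up or down, compound 4 is expected to stay close to compound 3, an expected step of a number 2.5 percentage points higher from compound 3 to compound 4 (within the scatter). Compound 4 is therefore estimated at 10%, with a range from 2% to 20%.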

Compound 4, percent growth inhibition at one concentration: 5.37%
The estimate for compound 4 lay 4.6 percentage points above the measured number; the range from low to high includes it.
By their numbers in this assay, from the lowest: compounds 4, 3, 2 and 1 (each within the scatter of the next).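

Among the compounds shown here, this is the first measured step at this position that replaces a whole aromatic ring rather than a halogen on it. In this assay, pyridin-2-yl in place of 4-methylphenyl on the five-membered aromatic ring gives a number 2.1 percentage points lower from compound 3 to compound 4 (within the scatter). Putting a ring nitrogen, and with it a hydrogen-bond acceptor, into this ring therefore leaves the two compounds indistinguishable in this read-out, and nothing available here explains that result.

On these data alone, whether a group of another kind at this position, such as an aminomethyl group, a carboxylic acid or a longer alkyl chain, would shift the number beyond the scatter remains open. So does whether the same ring swap would give a similar result with the nitrile-bearing phenyl of compound 1 in place of the methylsulfonyl-bearing one.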